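Notes on the aryl ether series: compound 3 to compound 4

A few compounds are considered here, and "the series" means these few. Any claim that something is new, unique, unknown or untested is made for them only; others in the source may bear on it.

Compound 3 `c1ccc(-c2ncc[nH]2)c(OCC2=NCCN2)c1` stands highest of the three measured compounds in a functional assay with Alpha-1A adrenergic receptor (Homo sapiens) as the target, read by calcium flux (on this read-out lower numbers stand for smaller maximal responses and higher numbers for larger maximal responses), with 122%. Compound 1 `c1cncc(-c2ccccc2OCC2=NCCN2)c1` gives 109% in this assay, and compound 2 `c1ccc(-c2ccoc2)c(OCC2=NCCN2)c1` gives 104%. Both steps into compound 3 run upward and beyond the scatter: a number 13 percentage points higher from compound 1 to compound 3 (beyond the scatter) and a number 18 percentage points higher from compound 2 to compound 3 (beyond the scatter). Between the other two, a number 5 percentage points lower from compound 1 to compound 2 (within the scatter), so compound 1 and compound 2 lie within the scatter of each other.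

Compound 4 `Cc1csc(-c2ccccc2OCC2=NCCN2)n1` differs from compound 3 in one place: 4-methyl-1,3-thiazol-2-yl in place of 1H-imidazol-2-yl on an aromatic carbon. Within the data shown here, the steps that bear on this are the two that put 1H-imidazol-2-yl in place of another heteroaryl ring on the same aromatic carbon, a number 13 percentage points higher from compound 1 to compound 3 (beyond the scatter) and a number 18 percentage points higher from compound 2 to compound 3 (beyond the scatter); the present step goes the other way, from 1H-imidazol-2-yl to a different ring. The two rings without the imidazole, in compound 1 and compound 2, gave numbers within the scatter of each other, so a modest downward step back toward that level is expected in this assay, about a number 14 percentage points lower from compound 3 to compound 4 (beyond the scatter). Compound 4 is therefore estimated at 108% in this assay, within a range of 94% to 122%.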

Compound 4, largest response reached (reported as maximum), in percent of the reference or control that the assay uses: 104%
Compound 4: the middle estimate sits 4 percentage points above what was measured; the measured number falls inside the stated range.
By their numbers in this assay, from the lowest: compounds 2, 4 and 1 (each within the scatter of the next); then compound 3.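

In this assay there is a number 18 percentage points lower from compound 3 to compound 4 (beyond the scatter) and so 4-methyl-1,3-thiazol-2-yl does not keep the level of 1H-imidazol-2-yl on this aromatic carbon, while there is no change at the digits printed from compound 2 to compound 4 (within the scatter) and a number 5 percentage points lower from compound 1 to compound 4 (within the scatter) so the new ring cannot be told apart from furan-3-yl or pyridin-3-yl, and compound 3 alone stands clear of the other three compounds. Compound 3 and compound 4 both carry one five-membered aromatic ring with 2 hetero atoms at this place, so that feature alone does not set the higher number, and the leaving and entering rings differ in their counts of hydrogen-bond donors and acceptors, in sulfur and in the methyl group. No measurement at hand gives a cause for this step.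

As far as these compounds go, the hydrogen-bond donor of 1H-imidazol-2-yl, the ring sulfur and the methyl group change together in this one step, and which of them goes with the gap stays open. An unsubstituted 1,3-thiazol-2-yl, a 1-methyl-1H-imidazol-2-yl, or a simple amine or carboxylic acid on the same aromatic carbon would take these apart, and how such groups would read in this assay is unknown from the compounds shown.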